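Methoxy on the Side Ring and Liver Microsome Clearance

The source may report more compounds than this note shows. Statements on the series, on what has been measured and on what is new or still open speak of the compounds shown alone.

Of the compounds shown here, three built on a sulfonamide-bearing core have been measured, and a fourth awaits its number. Compound 1 `C[C@H](Nc1cc(F)c(S(=O)(=O)Nc2cscn2)cc1Cl)c1ccccc1F` gives 51 mL/min/kg in an ADME assay on microsomes from liver (Homo sapiens) for metabolic stability, read by LC-MS, using NADPH, with a stated time of 60 min, tested at 1 uM; a lower number here means slower removal, a higher number faster removal of the compound. Compound 2 `COc1ccc(F)c([C@H](C)Nc2cc(F)c(S(=O)(=O)Nc3cscn3)cc2Cl)c1` carries one change on the side ring, (methoxy in place of hydrogen on an aromatic carbon), and in this assay compound 2 gives 54 mL/min/kg. The step of a 1.1-fold higher number from compound 1 to compound 2 (0.02 log units; within the scatter) shows that adding the methoxy group here leaves the removal rate essentially where it was.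

Compound 3 `C[C@H](Nc1cc(F)c(S(=O)(=O)Nc2cscn2)c(F)c1)c1ccccc1F` has a different core from compound 1; the difference between the two cores is not broken down here. In this assay compound 3 gives 27 mL/min/kg, a number that lies within the usual scatter of the values for compound 1 and compound 2, so no order among the three can be claimed.

Compound 4 `COc1ccc(F)c([C@H](C)Nc2cc(F)c(S(=O)(=O)Nc3cscn3)c(F)c2)c1` is built from compound 3 by the same change that turned compound 1 into compound 2: methoxy in place of hydrogen on an aromatic carbon. The place is the same word for word in both pairs, so this is the same change, made on a second core. Because the step of a 1.1-fold higher number from compound 1 to compound 2 (0.02 log units; within the scatter) was small, the expected step from compound 3 to compound 4 is a 1.1-fold higher number from compound 3 to compound 4 (0.05 log units; within the scatter), also small. Compound 4 is therefore estimated to give 30 mL/min/kg in this assay, with a likely range from 15 mL/min/kg to 60 mL/min/kg. The measured number will show whether the change behaves alike on the two cores.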

Compound 4, clearance in the Homo sapiens assay: 21 mL/min/kg
The estimate for compound 4 lay 1.4-fold (0.15 log units) above the measured number; the measured number falls inside the stated range.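

In the Homo sapiens assay compound 3 gives 27 mL/min/kg and compound 4 gives 21 mL/min/kg and methoxy in place of hydrogen on the core of compound 3 gives a 1.3-fold lower number from compound 3 to compound 4 (0.11 log units; within the scatter) and setting this beside the same change on the core of compound 1 gives the following comparison: the same change on two cores in the Homo sapiens assay, a 1.1-fold higher number (0.02 log units; within the scatter) from compound 1 to compound 2 and a 1.3-fold lower number (0.11 log units; within the scatter) from compound 3 to compound 4, 1.4-fold (0.13 log units) apart, within the scatter of two such steps On these two cores the change therefore reads alike, since neither step can be told apart from the spread of repeated measurements. In a physicochemical assay for lipophilicity, read by LC-MS, in phosphate buffer, measured as octanol-water partition, with a stated time of 1 h, at pH 7.4 (on this read-out lower numbers stand for lower lipophilicity and higher numbers for higher lipophilicity), compound 3 gives 2.9 and compound 4 gives 2.9 and the step of no change at the digits printed from compound 3 to compound 4 (within the scatter) is the only one available there. This does not show that methoxy is without effect on every core in the series, because two pairs are a narrow base, and steps this small cannot separate a slight real shift from none at all, nor do they explain why the two cores agree.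

The compounds shown cover only one swap, 2-fluorophenyl to 2-fluoro-5-methoxyphenyl, so it remains open whether methoxy at another place on that ring would also leave the clearance reading within the scatter. Going by these compounds, it also remains open whether a different group at the same place, such as an amine, a carboxylic acid or a longer chain like ethoxy, would carry from one core to the other in the same way.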